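The source may hold more compounds than are shown below. What is called first, only, known or untested is meant among the compounds shown, and "the series" means these compounds.

Measured in an ADME assay on BJ cells (Homo sapiens) for cytotoxicity, with a stated time of 72 h; a lower number here means that less compound is needed, a higher number that more compound is needed for the effect:
- compound 1 `COc1cc2ncnc(-n3nc(-c4ccccn4)nc3N)c2cc1N`: "not determined" (no result reported)
- compound 2 `COc1cc2ncnc(-n3nc(-c4ccccn4)nc3N)c2cc1OCCNC(=O)OC(C)(C)C`: > 15000 nM

In this assay compound 2 gives > 15000 nM, which is a limit and not a number. Among the measured compounds shown here, compound 1 has no reported result, so no measured step is available.

Compound 3 `CCOC(=O)NCCCOc1cc2c(-n3nc(-c4ccccn4)nc3N)ncnc2cc1OC` differs from compound 2 as follows: ((ethoxycarbonyl)amino)methyl in place of (tert-butoxycarbonyl)amino on a saturated chain carbon, two bonds along the chain from an oxygen on an aromatic ring.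

No change beyond the scatter is expected in this assay, and the result may again be only a limit. The expected step is a step that the limit leaves unreadable from compound 2 to compound 3. For compound 3 the estimate is 20000 nM, with an expected range of 9000 nM to 40000 nM.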

Compound 3, half-maximal effective concentration: > 11000 nM
Compound 3: only a limit was reported; the forecaster's own chance of this, stated with the estimate: 70%; the middle value is on the limit's open side.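

In this assay compound 2 gives > 15000 nM as a limit. Among the compounds shown here, compound 3 gives > 11000 nM as a limit too, and no step between the two can be read. Where either value actually lies stays open, and with it any effect of ((ethoxycarbonyl)amino)methyl in place of (tert-butoxycarbonyl)amino.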